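The source may report more compounds than this note shows. Statements on the series, on what has been measured and on what is new or still open speak of the compounds shown alone.

Measured so far:
- compound 1 `COc1cc(-c2nnc3c(OC(C)C)cc(-c4ccc5c(ccn5C)c4)cn23)cc(OC)c1OC`: 204 nM
- compound 2 `COc1cc(-c2nnc3c(OC4COC4)cc(-c4ccc5c(ccn5C)c4)cn23)cc(OC)c1OC`: 1900 nM

Both values come from a functional assay on MCF7 cells (Homo sapiens) for antiproliferative activity, read by MTT assay, with a stated time of 48 h; a lower number here means a stronger inhibitor, a higher number a weaker inhibitor. Of these two, compound 2 has the higher number, 1900 nM, which makes it the weaker inhibitor of the pair.

Compound 3 `COc1cc(-c2nnc3c(OC4CC4)cc(-c4ccc5c(ccn5C)c4)cn23)cc(OC)c1OC` keeps the core of compound 2 and alters one group: cyclopropyl in place of oxetan-3-yl on an oxygen on an aromatic ring. In short, cyclopropyl stands in place of oxetan-3-yl on an oxygen on an aromatic ring.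

Among the measured compounds shown here, only one measured step bears on this change: a 9.3-fold higher number from compound 1 to compound 2 (0.97 log units; beyond the scatter). That step is beyond the usual scatter and arose when oxetan-3-yl replaced isopropyl. Compound 3 swaps oxetan-3-yl for cyclopropyl, a group of carbon only, and so resembles compound 1 in that respect. However, cyclopropyl is not isopropyl, and a single pair offers thin evidence. A lower number is therefore expected in this assay, with a step somewhat smaller than the measured one.

The estimated change is a 6.6-fold lower number from compound 2 to compound 3 (0.82 log units; beyond the scatter). For compound 3, the estimated value is 290 nM, with an expected range from 100 nM to 800 nM.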

Compound 3, half-maximal inhibitory concentration: 118 nM
Beside the measured number, compound 3's estimate is 2.5-fold (0.39 log units) above it; measured number inside the range.
By their numbers in this assay, from the lowest: compounds 3 and 1 (each within the scatter of the next); then compound 2.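

In this assay, replacing oxetan-3-yl with cyclopropyl on this oxygen gives a 16-fold lower number from compound 2 to compound 3 (1.21 log units; beyond the scatter) and so recovers all of the ground lost with oxetan-3-yl. The comparison with isopropyl gives a 1.7-fold lower number from compound 1 to compound 3 (0.24 log units; within the scatter) and so does not separate the two carbon-only groups, which means that a ring on this oxygen is not itself a problem, since cyclopropyl is also a ring. Among these three compounds, the weaker result belongs only to the group whose ring contains an oxygen atom and a hydrogen-bond acceptor, though this link rests on a single compound and no measurement here explains it.

Oxetan-3-yl also differs from cyclopropyl in ring size, so cyclobutyl, a four-membered ring of carbon only, would show whether the ring oxygen or the larger ring goes with the weaker number. The compounds shown also leave open how far this position accepts other groups, such as a longer chain like n-butyl or a chain ending in an amine.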